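Moving the piperidine attachment point on a naphthyl-oxadiazole

A few compounds are considered here, and "the series" means these few. Any claim that something is new, unique, unknown or untested is made for them only; others in the source may bear on it.

Measured compounds:
compound 1 `c1ccc2cc(-c3noc(C4CCNCC4)n3)ccc2c1` with 580 nM
compound 2 `OCCCN1CCC(c2nc(-c3ccc4ccccc4c3)no2)CC1` with 40400 nM

In an assay on HepG2 cells for antagonist activity at Bile acid receptor (Homo sapiens), read by a luciferase reporter (on this read-out lower numbers stand for stronger inhibition and higher numbers for weaker inhibition), compound 1 gives the lowest number of the two measured compounds; its nearest neighbour is compound 2, reached by a 70-fold higher number from compound 1 to compound 2 (1.84 log units; beyond the scatter). Within the data shown here, that step puts a 3-hydroxypropyl group on the amine nitrogen of the ring and is the only measured step available.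

Compound 3 `c1ccc2cc(-c3noc([C@@H]4CCCCN4)n3)ccc2c1` has not yet been measured. It differs from compound 1 by piperidin-2-yl in place of piperidin-4-yl on an aromatic carbon. The ring that carries the amine is kept, but it is joined to the core through a different ring carbon, so the amine nitrogen sits at a different distance from the core.

Among the measured compounds shown here, no measured step bears on this change: the step from compound 1 to compound 2 alters the nitrogen itself, not where the ring is attached. The direction is therefore uncertain; a change in attachment point of this kind is expected to cost some potency rather than to gain it, but with a wide range. Compound 3 is expected to reach 2000 nM (range 400 nM to 15000 nM), that is a 3.4-fold higher number from compound 1 to compound 3 (0.54 log units; beyond the scatter).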

Compound 3, half-maximal inhibitory concentration in the Bile acid receptor assay: 127 nM
Beside the measured number, compound 3's estimate is 16-fold (1.20 log units) above it, outside the stated range (below it).
By their numbers in the Bile acid receptor assay, from the lowest: compound 3; then compound 1; then compound 2.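

Among these compounds, in the Bile acid receptor assay, the step so far had changed only the amine nitrogen, whereas this one keeps the ring and its free nitrogen and moves only the point of attachment, giving a 4.6-fold lower number from compound 1 to compound 3 (0.66 log units; beyond the scatter), with compound 1 at 580 nM and compound 3 at 127 nM. This position therefore responds to where the ring is joined to the core, and piperidin-2-yl serves at least as well here as piperidin-4-yl, so the arrangement in compound 1 is not the only one that works. In a physicochemical assay for lipophilicity, read by LC-MS (on this read-out higher numbers stand for higher lipophilicity and lower numbers for lower lipophilicity), compound 1 gives 0.34 and compound 3 gives 0.58; the same change gives a number 0.24 log units higher from compound 1 to compound 3 (within the scatter), so the two compounds cannot be told apart on that read-out, and nothing available here accounts for the lower inhibition number.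

Among the compounds shown here, it remains open whether the gain belongs to piperidin-2-yl in general or to the single defined stereocentre of compound 3, a question that the opposite stereocentre would address, and whether piperidin-3-yl or the smaller pyrrolidin-2-yl would behave alike. From the compounds shown here alone, it is also open whether a 3-hydroxypropyl group on the nitrogen of compound 3 would carry the same penalty in the Bile acid receptor assay as a 70-fold higher number from compound 1 to compound 2 (1.84 log units; beyond the scatter).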